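Second ethyl on the amide nitrogen of compound 2

The compounds below may be only part of what the source reports. "The series", "measured", "known", "first", "only" and "open" are said of these compounds alone.

Measured so far:
compound 1 `COc1cc2c(cc1OC)C(CC(=O)O)CC2` — 23.9%
compound 2 `CCNC(=O)CC1CCc2cc(OC)c(OC)cc21` — 26.6%

Among the compounds with values here, compound 2 holds the higher of the two numbers in a functional assay on the whole organism (strain Wistar) for inhibition, with Rattus norvegicus as the target, read by paw edema, with stated times of 60 min and 4 h, at a dose of 100 mg/kg by the oral route (a lower number here means less inhibition, a higher number more inhibition at the dose given (going by the name of the read-out)), but the only step measured, a number 2.7 percentage points higher from compound 1 to compound 2 (within the scatter), lies within the scatter, so compound 2 and compound 1 cannot be told apart. Compound 3 `CCN(CC)C(=O)CC1CCc2cc(OC)c(OC)cc21` differs from compound 2 by ethyl in place of hydrogen on an amide-type nitrogen. Within the data shown here, the one relevant step, ethylamino for hydroxy on the carbonyl carbon, a number 2.7 percentage points higher from compound 1 to compound 2 (within the scatter), was within the scatter; adding a second ethyl at the same amide is expected to give no step beyond the scatter, a number 0.4 percentage points higher from compound 2 to compound 3 (within the scatter). For compound 3 the estimated value is 27%, expected between 12% and 42%.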

Compound 3, a percentage reported as inhibition, in the whole organism at one dose (the size of the read-out at that dose, not a potency): 37.5%
Compound 3: middle estimate off by 10.5 percentage points, on the low side, and the stated range covers the measured number.
By their numbers in this assay, from the lowest: compounds 1 and 2 (each within the scatter of the next); then compound 3.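

In this assay the amide-type nitrogen responds to substitution: ethyl in place of hydrogen gives a step beyond the scatter (a number 10.9 percentage points higher from compound 2 to compound 3 (beyond the scatter)). Diethylamino in place of hydroxy on the carbonyl carbon also clears the scatter (a number 13.6 percentage points higher from compound 1 to compound 3 (beyond the scatter)), whereas ethylamino in place of hydroxy did not. No available data bear on the reason for either step.

Open, from the compounds shown here alone, is whether a longer chain such as propyl on this nitrogen moves the number further. Going by these compounds, the plain primary amide, with both ethyl groups replaced by hydrogen, also remains open.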